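The source may hold more compounds than are shown below. What is called first, only, known or untested is meant among the compounds shown, and "the series" means these compounds.

Compound 1 `CC(Sc1nnc(-c2ccncc2)s1)C(=O)Nc1ccc(Cl)cc1Cl` gives > 50000 nM in an ADME assay on BHK-21 cells (Mesocricetus auratus) for cytotoxicity, with a stated time of 3 days; a lower number here means that less compound is tolerated, a higher number that more compound is tolerated; this value is a limit of the assay, not a measured number.
Compound 2 `CC(Sc1nnc(-c2ccncc2)s1)C(=O)Nc1c(Cl)cccc1Cl` gives > 50000 nM in this assay; this too is a limit.
Compound 3 `CC(CSc1nnc(-c2ccncc2)s1)C(=O)Nc1c(Cl)cccc1Cl` gives > 50000 nM in this assay; again only a limit.

Every measured value therefore sits at the limit of > 50000 nM in this assay, at which 3 of the 3 values shown sit. Compound 2 and compound 1 differ by 2,4-dichlorophenyl in place of 2,6-dichlorophenyl on an amide-type nitrogen, and the step that the two limits leave unreadable from compound 2 to compound 1 cannot be read in size, as both ends are limits. Compound 2 and compound 3 differ in their cores; that difference is not broken down here. Compound 4 `CC(CSc1nnc(-c2ccncc2)s1)C(=O)Nc1ccc(Cl)cc1Cl` has not yet been measured. Among the compounds with values here, it arises from compound 3 by 2,4-dichlorophenyl in place of 2,6-dichlorophenyl on an amide-type nitrogen, which is the same change as the one from compound 2 to compound 1, at the same place. Because all three measured compounds rest at the limit of > 50000 nM in this assay, at which 3 of the 3 values shown sit, the step from compound 3 to compound 4 is expected to be about a step that the limit leaves unreadable from compound 3 to compound 4, with the result most likely reported again only as a limit. Compound 4 is thus estimated to give 80000 nM in this assay.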

Compound 4, half-maximal cytotoxic concentration: > 50000 nM
Compound 4: no number, only a limit; the forecaster's own chance of this, stated with the estimate: 85%; the middle value does not contradict the limit.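

The step from compound 3 to compound 4 cannot be read, and neither can the one from compound 2 to compound 1, because all of these results are limits and not numbers: the limit of > 50000 nM in this assay, at which 4 of the 4 values shown sit.

The compounds shown leave open at what concentration any of them would harm the cells, and whether swapping 2,6-dichlorophenyl for 2,4-dichlorophenyl changes that concentration at all.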